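The source may hold more compounds than are shown below. What is called first, only, known or untested is meant among the compounds shown, and "the series" means these compounds.

Measured in a functional assay on T47D cells (Homo sapiens) for inhibition, read by CCK-8 assay, with a stated time of 72 h, tested at 10 uM; on this read-out lower numbers stand for less inhibition of growth and higher numbers for more inhibition of growth at the one concentration tested:
- compound 1 `CN(C)C(=O)c1cc2cnc(Nc3ccc(NC(=O)C4(C(=O)Nc5cccc(Cl)c5)CC4)cc3)nc2n1C1CCCC1`: 92.6%
- compound 2 `CN(C)C(=O)c1cc2cnc(Nc3ccc(NC(=O)C4(C(=O)Nc5ccc(Br)cc5)CC4)cc3)nc2n1C1CCCC1`: 94.3%

Compound 2, at 94.3%, stands level with compound 1 within the scatter, and both values are high on this read-out. Compound 3 `CN(C)C(=O)c1cc2cnc(Nc3ccc(NC(=O)C4(C(=O)Nc5ccc(Cl)c(C(F)(F)F)c5)CC4)cc3)nc2n1C1CCCC1` carries 4-chloro-3-(trifluoromethyl)phenyl in place of 4-bromophenyl on an amide-type nitrogen. Within the data shown here, the only measured step at this place is a number 1.7 percentage points higher from compound 1 to compound 2 (within the scatter), which lies within the scatter. No step beyond the scatter is therefore expected in this assay. The estimated change is a number 3.3 percentage points lower from compound 2 to compound 3 (within the scatter). Compound 3 is expected at 91%, with an estimated range of 80% to 99%.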

Compound 3, percent growth inhibition at one concentration: 55.8%
The estimate for compound 3 lay 35.2 percentage points above the measured number; the measured number lies below the stated range.
By their numbers in this assay, from the lowest: compound 3; then compounds 1 and 2 (each within the scatter of the next).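

In this assay the aryl group on the amide-type nitrogen proves sensitive to change: 4-chloro-3-(trifluoromethyl)phenyl gives a large loss of growth inhibition (a number 38.5 percentage points lower from compound 2 to compound 3 (beyond the scatter)) and (a number 36.8 percentage points lower from compound 1 to compound 3 (beyond the scatter)). The exchange of 3-chlorophenyl for 4-bromophenyl had shown no such loss, so this position tolerates some aryl changes but not all. Nothing at hand bears on the reason for this drop.
Going by these compounds, whether the trifluoromethyl group alone on the phenyl ring would give the same loss remains open. Also open, on these data alone, is how a methoxy or an amino group would behave at this place.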